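Stereo-unassigned counterpart of compound 2 in the binding assay

The compounds below may be only part of what the source reports. "The series", "measured", "known", "first", "only" and "open" are said of these compounds alone.

Compound 2 `Cn1ncc(Cl)c1-c1cc(C(=O)N[C@H]2CNCC[C@@H]2c2ccc(C(F)(F)F)cc2)oc1Cl` gives 127 nM in a binding assay for inhibition of RAC-alpha serine/threonine-protein kinase (Homo sapiens), read by HTRF, with a stated time of 1 h; on this read-out higher numbers stand for weaker inhibition and lower numbers for stronger inhibition; this is the highest of the three numbers recorded. Compound 1 `Cn1ncc(Cl)c1-c1cc(C(=O)N[C@@H]2CN[C@H](CCn3cncn3)C[C@H]2c2ccc(Cl)c(Cl)c2)oc1Cl` gives 4.47 nM, and compound 3 `Cn1ncc(Cl)c1-c1cc(C(=O)N[C@@H]2CN[C@H](CC(=O)NC3CC3)C[C@H]2c2ccc(Cl)c(Cl)c2)oc1Cl` gives 3.95 nM. The gap from compound 2 to compound 1 and the gap from compound 2 to compound 3 both lie beyond the scatter. For the measured compounds named here, the single measured step, a 1.1-fold lower number from compound 1 to compound 3 (0.05 log units; within the scatter), concerns a change on the side chain and has no bearing on the present question. Compound 4 `Cn1ncc(Cl)c1-c1cc(C(=O)NC2CNCCC2c2ccc(C(F)(F)F)cc2)oc1Cl` differs from compound 2 as follows: the two compounds have the same atoms and bonds; at least one stereo element is drawn with a configuration in one of them and without one in the other: 2 of 2 stereo elements differ; a stereocentre at a saturated ring carbon is drawn R in compound 2 and without a configuration in compound 4; a stereocentre at a saturated ring carbon is drawn R in compound 2 and without a configuration in compound 4. Going by the values given here, no measured pair shows what leaving both stereocentres undefined does. Since compound 2 carries the defined configuration, compound 4 is expected to give a number at or somewhat above it, a step of a 1.7-fold higher number from compound 2 to compound 4 (0.24 log units; within the scatter). The estimate for compound 4 is 220 nM, within the range 100 nM to 600 nM.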

Compound 4, half-maximal inhibitory concentration: 7.2 nM
The estimate for compound 4 lay 31-fold (1.49 log units) above the measured number; the whole stated range lies above it.
By their numbers in this assay, from the lowest: compounds 3, 1 and 4 (each within the scatter of the next); then compound 2.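

In this assay the step is an 18-fold lower number from compound 2 to compound 4 (1.25 log units; beyond the scatter), with atoms and bonds unchanged, so stereochemistry at the two saturated ring carbons alone accompanies a large difference. For the compounds shown here, the gain can be traced only to one thing: the fact that one of compounds 2 and 4 is drawn with a defined configuration and the other without, at the place where they differ If compound 4 is a mixture, the stronger inhibition probably lies with a configuration other than the one drawn in compound 2.

Which single stereoisomer accounts for the number of compound 4 remains open. Also open, from the compounds shown here alone, is whether a nitrile in place of trifluoromethyl would hold that number.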